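The compounds below may be only part of what the source reports. "The series", "measured", "known", "first", "only" and "open" are said of these compounds alone.

Of the compounds shown here, three that share one core have been measured in a functional assay on PC-3 cells (Homo sapiens) for antiproliferative activity, read by MTT assay, tested at 5 uM; on this read-out higher numbers stand for a stronger effect at the one concentration tested and lower numbers for a weaker effect. Compound 1 `COc1cc(C2=NN(C(C)=O)C(c3ccccc3C(F)(F)F)O2)cc(OC)c1OC` gives 15.2%, compound 2 `COc1cc(C2=NN(C(C)=O)C(c3ccc(F)c(F)c3)O2)cc(OC)c1OC` gives 46.9%, and compound 3 `COc1cc(C2=NN(C(C)=O)C(c3ccc(F)cc3)O2)cc(OC)c1OC` gives 0.1%. Compound 3 stands lowest of the three: the change a number 15.1 percentage points lower from compound 1 to compound 3 (beyond the scatter) and the change a number 46.8 percentage points lower from compound 2 to compound 3 (beyond the scatter) both lie beyond the scatter, the second of them large. Compound 4 `COc1cc(C2=NN(C(C)=O)C(c3c(Cl)cccc3Cl)O2)cc(OC)c1OC` is the next to be measured and differs from compound 3 in one place: 2,6-dichlorophenyl in place of 4-fluorophenyl on a saturated ring carbon.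

Going by the values given here, no measured pair swaps these two groups directly, so the guidance is indirect. The large step of a number 31.7 percentage points higher from compound 1 to compound 2 (beyond the scatter) shows that what sits on this phenyl ring can move the read-out strongly, and compound 3 already sits at the floor, so a fall is hardly possible. A modest rise is expected, a number 14.9 percentage points higher from compound 3 to compound 4 (beyond the scatter), because compound 1 gives 15.2% with a differently substituted phenyl. Compound 4 is estimated at 15%, in a range from 0% to 40%.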

Compound 4, a percentage reported as inhibition, at one concentration (the size of the read-out at that concentration, not a potency): -2.2%
Beside the measured number, compound 4's estimate is 17.2 percentage points above it; measured number below the stated range.
By their numbers in this assay, from the lowest: compounds 4 and 3 (each within the scatter of the next); then compound 1; then compound 2.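

In this assay, 2,6-dichlorophenyl in place of 4-fluorophenyl on this saturated ring carbon gives no change that can be told from scatter (a number 2.3 percentage points lower from compound 3 to compound 4 (within the scatter)), so a second, differently substituted phenyl ring also sits at the bottom of the series. Set against the other two rings, the same group gives clear falls (a number 49.1 percentage points lower from compound 2 to compound 4 (beyond the scatter); a number 17.4 percentage points lower from compound 1 to compound 4 (beyond the scatter)), which leaves 3,4-difluorophenyl ahead of all three other rings and shows that halogen atoms on this phenyl ring do not by themselves give a strong read-out. Nothing available explains why these rings differ.

Every ring shown here carries fluorine or chlorine, so it stays open how a plain phenyl ring, or one bearing an amine or a carboxylic acid, would read. On these data alone, it also stays open whether a single chloro group would read like the pair in compound 4.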